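Hydroxy for methyl on the saturated chain

The source may report more compounds than this note shows. Statements on the series, on what has been measured and on what is new or still open speak of the compounds shown alone.

Compound 3 `COc1ccc(CCC(C)(C)C)c(N2CCC(COc3cccc(C(CC(=O)O)C4CC4)c3)CC2)c1` carries the 3,3-dimethylbutyl group on an aromatic carbon of the shared core. In a functional assay on cells for agonist activity at Free fatty acid receptor 1 (Homo sapiens), read by FLIPR and calcium flux, with a stated time of 60 min (on this read-out higher numbers stand for larger maximal responses and lower numbers for smaller maximal responses), compound 3 gives 110%. On paper this is the smallest of the three numbers, but the gaps to both neighbours lie within the scatter: compound 1 `COc1ccc(F)c(N2CCC(COc3cccc(C(CC(=O)O)C4CC4)c3)CC2)c1`, with fluoro at that aromatic carbon, gives 114% in this assay, and compound 2 `COc1ccc(C(C)C)c(N2CCC(COc3cccc(C(CC(=O)O)C4CC4)c3)CC2)c1`, with isopropyl there, gives 117%. The steps between them are a number 3 percentage points higher from compound 1 to compound 2 (within the scatter), a number 4 percentage points lower from compound 1 to compound 3 (within the scatter) and a number 7 percentage points lower from compound 2 to compound 3 (within the scatter), none beyond the scatter; the maximal response in this assay has so far stayed flat across every change at this aromatic carbon.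

Compound 4 `COc1ccc(CCC(C)(C)O)c(N2CCC(COc3cccc(C(CC(=O)O)C4CC4)c3)CC2)c1` differs from compound 3 by hydroxy in place of methyl on a saturated chain carbon bound to three saturated chain carbons. Among the measured compounds shown here, no measured step swaps methyl for hydroxy, and none touches the chain itself, so this change is of a different kind from the three recorded steps. For the measured compounds named here, the only guide is that fluoro, isopropyl and 3,3-dimethylbutyl at the aromatic carbon all gave the same maximal response within the scatter. The expected step is therefore none beyond the scatter, no change at the digits printed from compound 3 to compound 4 (within the scatter). Compound 4 is estimated at 110% in this assay, with a range from 98% to 122%.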

Compound 4, largest response reached (Emax), in percent of the reference or control that the assay uses: 109%
Estimate against measurement, compound 4: 1 percentage points above, within the range that was stated.
By their numbers in this assay, from the lowest: compounds 4, 3, 1 and 2 (each within the scatter of the next).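

In this assay, among the compounds shown here, the exchange of methyl for hydroxy on a saturated chain carbon bound to three saturated chain carbons gives a number 1 percentage points lower from compound 3 to compound 4 (within the scatter), the first reading for a change on the chain itself and for a hydrogen-bond donor and acceptor entering at this place. Set against the smaller groups on the aromatic carbon, 3-hydroxy-3-methylbutyl gives a number 8 percentage points lower from compound 2 to compound 4 (within the scatter) against isopropyl and a number 5 percentage points lower from compound 1 to compound 4 (within the scatter) against fluoro, so the tolerance for variation at this aromatic carbon now extends to a chain that ends in hydroxy, and all four compounds lie within the scatter of one another. No supporting measurement bears on this result.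

Open, going by these compounds, is whether an amine or a carboxylic acid at the end of this chain, or a longer chain carrying the hydroxy, would move the maximal response beyond the scatter. Also open, on these data alone, is whether these four compounds, alike in maximal response, are equally alike in the concentration needed to reach it, which this read-out does not tell.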